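Benzylsulfanyl in Place of Cyclohexyloxy: An Expected Potency

The source may report more compounds than this note shows. Statements on the series, on what has been measured and on what is new or still open speak of the compounds shown alone.

Measured compounds:
compound 1 `CC(C(=O)NCc1ccc(C(C)(C)C)nc1N1CCC(Cc2ccccc2)CC1)c1ccc(NS(C)(=O)=O)c(F)c1`: 0.3 nM
compound 2 `CC(C(=O)NCc1ccc(C(C)(C)C)nc1OC1CCCCC1)c1ccc(NS(C)(=O)=O)c(F)c1`: 2.5 nM

Of the compounds shown here, two have been measured in an assay on cells for antagonist activity at transient receptor potential cation channel subfamily V member 1 (Homo sapiens), read by FLIPR and calcium flux, with a stated time of 6 min; a lower number here means a stronger inhibitor, a higher number a weaker inhibitor. Compound 1, in this assay, gives 0.3 nM. Compound 2 gives 2.5 nM in this assay, the higher of the two numbers, and its gap to compound 1 lies beyond the scatter of repeated measurements.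

Compound 3 `CC(C(=O)NCc1ccc(C(C)(C)C)nc1SCc1ccccc1)c1ccc(NS(C)(=O)=O)c(F)c1` has not yet been measured. It differs from compound 2 at one place only: benzylsulfanyl in place of cyclohexyloxy on an aromatic carbon. Both groups that change here carry one hydrogen-bond acceptor and no donor, and both sit at the same position on the shared core.

For the measured compounds named here, no measured pair shows this exact change, so the size of the step must be estimated from what is in hand. Because compound 2 stands at 2.5 nM and the new group is of similar size, the step from compound 2 to compound 3 is expected to be small, a 1.3-fold lower number from compound 2 to compound 3 (0.10 log units; within the scatter), and not beyond the scatter. Compound 3 is therefore estimated at 2 nM in this assay, with a range from 0.5 nM to 8 nM.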

Compound 3, inhibition constant: 4 nM
Estimate against measurement, compound 3: 2.0-fold (0.30 log units) below; low and high end bracket the measured number.
By their numbers in this assay, from the lowest: compound 1; then compounds 2 and 3 (each within the scatter of the next).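

In this assay, putting benzylsulfanyl in place of cyclohexyloxy on the aromatic carbon next to the ring nitrogen gives a 1.6-fold higher number from compound 2 to compound 3 (0.20 log units; within the scatter), so the two groups cannot be told apart at this position. This single change exchanges oxygen for sulfur and a six-membered non-aromatic ring for a six-membered aromatic ring, and taken together these exchanges leave the number within the scatter. Nothing in the data shown gives a reason for this result.

The compounds shown leave open how far the sulfur and the aromatic ring each count on their own, as the two exchanges arrive together here and might offset each other; benzyloxy and cyclohexylsulfanyl would each separate them. Also open, from the compounds shown here alone, is how a much smaller group, such as methoxy or a primary amine, would read at this same position on the shared core.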